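A few compounds are considered here, and "the series" means these few. Any claim that something is new, unique, unknown or untested is made for them only; others in the source may bear on it.

Working notes on the series. In a functional assay on HepG2 cells (Homo sapiens) for antiproliferative activity, read by MTT assay, with a stated time of 72 h (on this read-out higher numbers stand for weaker inhibition and lower numbers for stronger inhibition), compound 1 `O=C(N/N=C/c1ccc(Cl)c(Cl)c1)Nc1ccc(Oc2ccnc3[nH]ccc23)c(F)c1` gives 3700 nM and compound 2 `O=C(N/N=C/c1cccn1CCCN1CCCCC1)Nc1ccc(Oc2ccnc3[nH]ccc23)c(F)c1` gives 2840 nM on the same read-out. Within the data shown here, these two values lie within the scatter of each other, so compound 2 stands together with compound 1 on the only numbers so far. Compound 3 `O=C(N/N=C/c1cccn1CCCN1CCCC1)Nc1ccc(Oc2ccnc3[nH]ccc23)c(F)c1` differs from compound 2 in one place, with pyrrolidin-1-yl in place of piperidin-1-yl on a saturated chain carbon, three bonds along the chain from an aromatic nitrogen. Among the measured compounds shown here, no measured pair shows this change, so the data give no direct size for it. In this assay no step beyond the scatter is expected, in either direction. The estimated step (a 1.1-fold lower number from compound 2 to compound 3 (0.02 log units; within the scatter)) is expected to remain small. For compound 3 the expected value is 2700 nM (estimated range 1300 nM to 5500 nM).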

Compound 3, half-maximal inhibitory concentration: 3500 nM
Compound 3: the middle estimate sits 1.3-fold (0.11 log units) below what was measured, and the stated range covers the measured number.
By their numbers in this assay, from the lowest: compounds 2, 3 and 1 (each within the scatter of the next).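

Swapping piperidin-1-yl for pyrrolidin-1-yl on a saturated chain carbon, three bonds along the chain from an aromatic nitrogen, gives in this assay a 1.2-fold higher number from compound 2 to compound 3 (0.09 log units; within the scatter). Among these compounds, this is the first direct size for this change, and it shows that going from the six-membered to the five-membered non-aromatic ring at this place leaves the read-out within the scatter. No measurement on hand bears on why the two rings read alike.

Still open, as far as these compounds go, is whether a different group at this place, such as morpholin-4-yl or dimethylamino, or a shorter chain carrying the same pyrrolidin-1-yl, would give a step beyond the scatter. Also open, from the compounds shown here alone, is whether the two rings would stay this close on cell lines other than this one.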